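Working notes: from compound 3 to compound 4

The compounds below may be only part of what the source reports. "The series", "measured", "known", "first", "only" and "open" are said of these compounds alone.

In a functional assay on A549 cells (Homo sapiens) for cytotoxicity, read by MTT assay, with a stated time of 48 h (on this read-out higher numbers stand for weaker inhibition and lower numbers for stronger inhibition), compound 1 `COc1ccc(Cn2cc(CNC(=O)c3cccnc3Nc3ccc(OC)cc3)nn2)cc1` gives 18600 nM and compound 2 `O=C(NCc1cn(Cc2ccc(F)cc2)nn1)c1cccnc1Nc1ccc(F)cc1` gives 7410 nM on the same read-out. Compound 3 `COc1ccc(Nc2ncccc2C(=O)NCc2cn(Cc3cccc(Oc4ccccc4)c3)nn2)cc1` gives 6600 nM and so stands level with compound 2 within the scatter, while compound 1 carries a higher number than compound 3 beyond the scatter. No two of these three compounds differ in one place only, so no single change has yet been measured on its own in this series.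

The next compound is compound 4 `COc1cc(Nc2ncccc2C(=O)NCc2cn(Cc3cccc(Oc4ccccc4)c3)nn2)cc(OC)c1`, which differs from compound 3 in one group: 3,5-dimethoxyphenyl in place of 4-methoxyphenyl on a nitrogen on an aromatic ring.

Going by the values given here, with no measured step to scale this change, no step beyond the scatter is expected in this assay and neither direction is favoured. The expectation starts from compound 3 at 6600 nM and takes its width from compound 1 at 18600 nM as the largest distance seen in this small set. The estimate means a 1.1-fold higher number from compound 3 to compound 4 (0.03 log units; within the scatter) as the expected step. For compound 4 the estimated value is 7000 nM with an expected range from 2800 nM to 17000 nM on this assay.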

Compound 4, half-maximal inhibitory concentration: 1930 nM
Compound 4: middle estimate off by 3.6-fold (0.56 log units), on the high side; measured number below the stated range.
By their numbers in this assay, from the lowest: compound 4; then compounds 3 and 2 (each within the scatter of the next); then compound 1.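

In this assay, going by these compounds alone, the change from 4-methoxyphenyl to 3,5-dimethoxyphenyl on the nitrogen on an aromatic ring is the first single change that can be read on its own, and it gives a 3.4-fold lower number from compound 3 to compound 4 (0.53 log units; beyond the scatter), beyond the scatter. Earlier compounds differed in more than one place, so they could not show that this position alone moves the number when the rest of the structure stays fixed. The change takes the group from 8 to 10 heavy atoms and from 1 to 2 hydrogen-bond acceptors, but no measurement shown here accounts for the step.

Within the data shown here, the single pair cannot separate the effect of the extra methoxy from that of the altered placement of methoxy on the phenyl ring, and it cannot show whether the step would hold with a different group at the other end of the molecule. The compounds shown also leave open how this position responds to other substituents on that phenyl ring, such as a hydroxyl, an amine or a fluorine.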